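This account rests on a few compounds, and the source may have more. Where it says the series, first, only, none or still open, it means among the compounds named here.

Measured so far in a functional assay on CHO cells for antagonist activity at sphingosine 1-phosphate receptor 2 (Homo sapiens), read by fluorescence; on this read-out higher numbers stand for weaker inhibition and lower numbers for stronger inhibition:

- compound 1, `CC(C)CC1(O)CCN(C(=O)Nc2cc(Oc3ccc(F)cc3)cc(Oc3ccc(C4(C(=O)O)CC4)cc3)c2)CC1`: 6.4 nM
- compound 2, `CC(C)CC1(O)CN(C(=O)Nc2cc(Oc3ccc(F)cc3)cc(Oc3ccc(C(C)(C)C(=O)O)cc3)c2)C1`: 5.2 nM

Among the compounds with values here, compound 1 holds the higher of the two numbers in this assay, but its gap to compound 2 lies within the scatter, so the two stand as equals on what is known; compound 2 carries a 2-carboxypropan-2-yl group and a smaller saturated ring where compound 1 carries the 1-carboxycyclopropyl group, and no single-point step links them.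

Compound 3, `CC(C)CC1(O)CCN(C(=O)Nc2cc(Oc3ccc(F)cc3)cc(Oc3ccc(C(=O)O)cc3)c2)CC1`, is not yet measured. It differs from compound 1 in one place: carboxy in place of 1-carboxycyclopropyl on an aromatic carbon. The acid itself stays; only the three-membered ring between the acid and the aromatic ring is removed. Nothing measured in the series speaks to this change directly. The expectation is a small loss in this assay, of a size that may not clear the scatter, since the group is trimmed rather than replaced, and compound 2 shows that the shape of the acid-bearing group can vary without a clear shift. Compound 3 is therefore expected at 13 nM, with a range from 4 nM to 45 nM, amounting to an estimated step of a 2.0-fold higher number from compound 1 to compound 3 (0.31 log units; beyond the scatter).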

Compound 3, half-maximal inhibitory concentration: 4 nM
Compound 3: middle estimate off by 3.3-fold (0.51 log units), on the high side; low and high end bracket the measured number.
By their numbers in this assay, from the lowest: compounds 3, 2 and 1 (each within the scatter of the next).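

In this assay, within the data shown here, a 1.6-fold lower number from compound 1 to compound 3 (0.20 log units; within the scatter) gives the first single-place reading at this position: on this aromatic carbon, para to a large group, 1-carboxycyclopropyl and carboxy stand as equals. In this pair, the three-membered ring of carbon only can therefore go with no readable shift in the number, while the carboxy and the rest of the core of compound 1 stay the same. No measurement available explains this result or shows whether the two compounds reach their numbers in the same way.

All three compounds shown keep a carboxylic acid on this aromatic ring, so they leave open whether the acid itself can be replaced here, for example by a methyl ester, a primary amide or a tetrazole. Also open, as far as these compounds go, is how a longer chain such as carboxymethyl or 2-carboxyethyl would read at the same place, and whether the equality of compound 1 and compound 3 would hold with other groups elsewhere on the core.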